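Swapping a Difluoropropyl Amide for an Ethylpyrimidine Amide

This account rests on a few compounds, and the source may have more. Where it says the series, first, only, none or still open, it means among the compounds named here.

Three compounds share one core and differ only in the group attached to a carbonyl carbon. In a functional assay on isolated protein for inhibition of Glucose-dependent insulinotropic receptor (Rattus norvegicus), read by HTRF and cAMP accumulation (a lower number here means that less compound is needed, a higher number that more compound is needed for the effect), compound 1 `Cc1nc(S(C)(=O)=O)ccc1Oc1ncnc(OC2CCN(C(=O)O[C@H](C)CF)CC2)c1F` gives 1520 nM, compound 2 `Cc1nc(S(C)(=O)=O)ccc1Oc1ncnc(OC2CCN(C(=O)SC3CC3)CC2)c1F` gives 126 nM, and compound 3 `CCC(F)(F)C(=O)N1CCC(Oc2ncnc(Oc3ccc(S(C)(=O)=O)nc3C)c2F)CC1` gives 69.2 nM, the lowest number of the three, although the step of a 1.8-fold lower number from compound 2 to compound 3 (0.26 log units; within the scatter) is small. Compound 4 `CCc1cnc(C(=O)N2CCC(Oc3ncnc(Oc4ccc(S(C)(=O)=O)nc4C)c3F)CC2)nc1` carries 5-ethylpyrimidin-2-yl in place of 1,1-difluoropropyl on a carbonyl carbon. For the measured compounds named here, the steps of a 12-fold lower number from compound 1 to compound 2 (1.08 log units; beyond the scatter) and a 22-fold lower number from compound 1 to compound 3 (1.34 log units; beyond the scatter) show that this position can shift the numbers strongly, but no measured compound carries an aromatic ring there, so the direction of the change is uncertain. For compound 4 a moderate upward step a 2.2-fold higher number from compound 3 to compound 4 (0.34 log units; beyond the scatter) is expected. Compound 4 is therefore estimated at 150 nM, with a likely range from 40 nM to 600 nM.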

Compound 4, half-maximal effective concentration: 40.8 nM
For compound 4 the middle estimate is 3.7-fold (0.57 log units) above the measured one, within the range that was stated.
By their numbers in this assay, from the lowest: compounds 4, 3 and 2 (each within the scatter of the next, the first and the last beyond it); then compound 1.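

An aromatic ring can sit on this carbonyl carbon without a loss: 5-ethylpyrimidin-2-yl in place of 1,1-difluoropropyl gives a 1.7-fold lower number from compound 3 to compound 4 (0.23 log units; within the scatter) in this assay, so these two groups cannot be told apart here. The same ring gives a 3.1-fold lower number from compound 2 to compound 4 (0.49 log units; beyond the scatter) and a 37-fold lower number from compound 1 to compound 4 (1.57 log units; beyond the scatter) against the two groups joined to the carbonyl through sulfur or oxygen. No measurement here explains why these groups give different numbers.

Whether the ethyl chain contributes at all remains open, since a pyrimidine without it is not among these compounds. Also open, on these data alone, is how a plain phenyl or pyridine ring would compare at this carbonyl carbon.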